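The source may report more compounds than this note shows. Statements on the series, on what has been measured and on what is new or still open speak of the compounds shown alone.

Measured so far in a functional assay on Raji cells (Homo sapiens); on this read-out higher numbers stand for weaker inhibition and lower numbers for stronger inhibition:
compound 1 `CCCCCCCCc1cn([C@H]2C[C@H](O)[C@@H](CO)O2)c(=O)[nH]c1=O` gives 140 ug/mL
compound 2 `CCCCc1cn([C@H]2C[C@H](O)[C@@H](CO)O2)c(=O)[nH]c1=O` gives > 500 ug/mL, a limit of the assay
compound 3 `CCCc1cn([C@H]2C[C@@H]3OP(=O)(O)OC[C@H]3O2)c(=O)[nH]c1=O` gives > 500 ug/mL, a limit of the assay

For the measured compounds named here, compound 2 therefore stands at the limit, with compound 1 the only value shown as a number. The change to compound 4 `CCCc1cn([C@H]2C[C@H](O)[C@@H](CO)O2)c(=O)[nH]c1=O` is hydrogen in place of methyl on a saturated chain carbon, three bonds along the chain from an aromatic carbon. Going by the values given here, the one measured step that bears on it, an at least 3.5-fold higher number from compound 1 to compound 2 (0.55 log units; beyond the scatter), runs in the same direction of a shorter chain and weakened inhibition. Compound 3 carries the same propyl chain on a different sugar part; its value is a limit. Because of the limit of > 500 ug/mL in this assay, at which 2 of the 3 values shown sit, compound 2 offers no number to move from, so for compound 4 a step that the limit leaves unreadable from compound 2 to compound 4 is expected, with the result most likely remaining a limit. Compound 4 is estimated at 900 ug/mL, within 350 ug/mL to 3000 ug/mL.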

Compound 4, concentration for 50% inhibition: > 500 ug/mL
Compound 4: only a limit was reported; the forecaster's own chance of this, stated with the estimate: 85%; the middle value is on the limit's open side.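

In this assay compound 4 gives > 500 ug/mL, a limit of the assay. With the propyl chain, the gap to the longer chain of compound 1 still holds, as an at least 3.5-fold higher number from compound 1 to compound 4 (0.55 log units; beyond the scatter) shows. The step between compound 2 and compound 4 cannot be read, so butyl to propyl at this position adds no size information, and the floor of the read-out now dominates the series: the limit of > 500 ug/mL in this assay, at which 3 of the 4 values shown sit.

On these data alone, it remains open at which chain length, shorter than that of compound 1 but longer than butyl, a number first appears. Also open, as far as these compounds go, is whether a chain longer than that of compound 1, or an amine at the chain end, gives a lower number.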